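This account rests on a few compounds, and the source may have more. Where it says the series, first, only, none or still open, it means among the compounds named here.

Compound 3 `Cn1nnnc1SCC(=O)N/N=C/c1ccccc1Br` has the lowest of the three numbers measured in a functional assay on A549 cells (Homo sapiens) for cytotoxicity, read by XTT assay, with a stated time of 24 h (on this read-out lower numbers stand for stronger inhibition and higher numbers for weaker inhibition), giving 2000000 nM. Compound 1 `Cn1nnnc1SCC(=O)N/N=C/c1ccccc1` gives 3160000 nM in this assay, and compound 2 `Cn1nnnc1SCC(=O)N/N=C/c1ccccc1Cl` gives 6320000 nM. Among the compounds with values here, the step of a 1.6-fold lower number from compound 1 to compound 3 (0.20 log units; within the scatter) lies within the scatter, so compound 3 and compound 1 cannot be told apart; only the step of a 3.2-fold lower number from compound 2 to compound 3 (0.50 log units; beyond the scatter) stands beyond the scatter. Compound 4 `Cn1nnnc1SCC(=O)N/N=C/c1ccccc1O` differs from compound 3 by hydroxy in place of bromo on an aromatic carbon. Within the data shown here, no measured step involves a hydroxy group: the measured steps replace hydrogen with a halogen, as in a 2.0-fold higher number from compound 1 to compound 2 (0.30 log units; within the scatter) and a 1.6-fold lower number from compound 1 to compound 3 (0.20 log units; within the scatter), or one halogen with another, as in a 3.2-fold lower number from compound 2 to compound 3 (0.50 log units; beyond the scatter), and all three are small. The hydroxy change therefore has no direct precedent among these compounds, and the expected step of a 1.5-fold higher number from compound 3 to compound 4 (0.18 log units; within the scatter) is kept small, with wide uncertainty in both directions. Compound 4 is accordingly expected to give 3000000 nM in this assay, with a range from 1000000 nM to 9000000 nM.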

Compound 4, half-maximal inhibitory concentration: > 10000000 nM
Compound 4: only a limit was reported; the forecaster's own chance of this, stated with the estimate: 10%; middle value at least 3.3-fold (0.52 log units) from the limit.
By their numbers in this assay, from the lowest: compounds 3, 1 and 2 (each within the scatter of the next, the first and the last beyond it). At a limit, above all of these: compound 4.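

In this assay, compound 4 gave a limit and not a number: the limit of > 10000000 nM in this assay, at which 1 of the 4 values shown sits. The earlier swaps among hydrogen, chloro and bromo on this aromatic carbon, ortho to a large group, moved the number only slightly, whereas hydroxy gives a clear shift towards weaker inhibition, with an at least 5.0-fold higher number from compound 3 to compound 4 (0.69 log units; beyond the scatter) and an at least 3.1-fold higher number from compound 1 to compound 4 (0.50 log units; beyond the scatter). The third comparison is less firm, with an at least 1.5-fold higher number from compound 2 to compound 4 (0.19 log units; that floor lies within the scatter), so the shift is not shown against every compound.

On these data alone, how far the true value of compound 4 lies past its limit stays unknown. Also open, as far as these compounds go, is whether the oxygen or the added hydrogen-bond donor goes with this shift, and a methoxy group or an amine at the same place would each give a further comparison.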